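The source may report more compounds than this note shows. Statements on the series, on what has been measured and on what is new or still open speak of the compounds shown alone.

Working notes on the series in a functional assay on the whole organism (blood, strain Wistar-Okamoto) with Rattus norvegicus as the target, with a stated time of 5 days; a higher number here means that more compound is needed for the effect, a lower number that less compound is needed. Among the compounds with values here, compound 2 `CC(C)/N=C(\NC#N)Nc1cccnc1` gives 2.5 mg/kg and stands lowest of the three numbers measured so far. Compound 1 `CC(C)CC/N=C(\NC#N)Nc1cccnc1` gives 20 mg/kg, and compound 3 `N#CN/C(=N\C1CCCC1)Nc1cccnc1` gives 20 mg/kg. The step of an 8.0-fold lower number from compound 1 to compound 2 (0.90 log units; beyond the scatter) and the step of an 8.0-fold higher number from compound 2 to compound 3 (0.90 log units; beyond the scatter) both lie beyond the scatter, whereas for no change at the digits printed from compound 1 to compound 3 (within the scatter). Among these three, the isopropyl group on the double-bonded nitrogen goes with the lowest number, and isopentyl and cyclopentyl at that position both go with the higher number; no compound in the set runs against this.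

Compound 4 `CC(C)(C)C(C)(C)/N=C(\NC#N)Nc1cccnc1` is not yet measured. It differs from compound 2 as follows: tert-butyl in place of hydrogen on a saturated chain carbon bound to a double-bonded nitrogen and two saturated chain carbons. The attachment to the double-bonded nitrogen is kept, but the group there is no longer isopropyl, which places compound 4 with compound 1 and compound 3 rather than with compound 2. Within the data shown here, the steps that bear on it are an 8.0-fold lower number from compound 1 to compound 2 (0.90 log units; beyond the scatter) and an 8.0-fold higher number from compound 2 to compound 3 (0.90 log units; beyond the scatter), each modest and beyond the scatter. A step of similar size in the same direction as that from compound 2 to compound 3 is therefore expected, written as a 6.0-fold higher number from compound 2 to compound 4 (0.78 log units; beyond the scatter). For compound 4 the estimated value in this assay is 15 mg/kg, with a range from 5 mg/kg to 50 mg/kg.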

Compound 4, minimum effective dose: 50 mg/kg
Compound 4: the middle estimate sits 3.3-fold (0.52 log units) below what was measured, and the stated range covers the measured number.
By their numbers in this assay, from the lowest: compound 2; then compounds 1 and 3 (each within the scatter of the next); then compound 4.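

In this assay, within the data shown here, tert-butyl in place of hydrogen on the saturated chain carbon bound to a double-bonded nitrogen and two saturated chain carbons gives a 20-fold higher number from compound 2 to compound 4 (1.30 log units; beyond the scatter) and is the only step graded large. The earlier compounds showed only replacement of the whole isopropyl group, with modest steps for isopentyl and cyclopentyl, whereas this step keeps that carbon and its two chain carbons in place and changes a single hydrogen, so the low number of compound 2 is shown to be lost through an addition at that carbon alone. Nothing given here explains the rise in the number at this position.

The compounds shown leave open whether a smaller group at that same carbon, such as a methyl group or an ethyl group, would give a step of intermediate size or one as large as that seen with tert-butyl. They also leave open how a hydroxyl group or an amine at that carbon would compare with the hydrogen of compound 2.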